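Methoxy to Benzylamino Swap in Two Related Cores

The source may hold more compounds than are shown below. What is called first, only, known or untested is meant among the compounds shown, and "the series" means these compounds.

Measured compounds:
compound 1, `NCCCCCNC1=Nc2ccccc2C(CC(=O)NCc2ccccc2)N1c1ccc(-c2ccccc2)cc1`, 80.1%
compound 2, `COC(=O)CC1c2ccccc2N=C(NCCCCCN)N1c1ccc(-c2ccccc2)cc1`, 97%
compound 3, `COC(=O)CC1c2ccccc2N=C(Nc2ccc(-c3ccccc3)cc2)N1CCCCCN`, 94.6%

In an assay on cells (Oocyte) for inhibition of Voltage-dependent T-type calcium channel subunit alpha-1H (Homo sapiens), tested at 100 uM (on this read-out higher numbers stand for more inhibition at the one concentration tested (going by the name of the read-out) and lower numbers for less inhibition), compound 2 gives 97% and compound 1 gives 80.1%. The change between them, (benzylamino in place of methoxy on a carbonyl carbon), made a step of a number 16.9 percentage points lower from compound 2 to compound 1 (beyond the scatter). Compound 3 is built from the same atoms as compound 2, joined differently; the difference between the two cores is not broken down here. In this assay compound 3 gives 94.6%, which lies within the scatter of compound 2.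

Compound 4, `NCCCCCN1C(Nc2ccc(-c3ccccc3)cc2)=Nc2ccccc2C1CC(=O)NCc1ccccc1`, is not yet measured. It differs from compound 3 by benzylamino in place of methoxy on a carbonyl carbon, the same change at the same place as the one already seen. Because that earlier change gave a number 16.9 percentage points lower from compound 2 to compound 1 (beyond the scatter), a step of similar size, a number 16.6 percentage points lower from compound 3 to compound 4 (beyond the scatter), is expected here. Compound 4 is therefore estimated at 78%, likely between 60% and 95%.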

Compound 4, a percentage reported as inhibition, at one concentration (the size of the read-out at that concentration, not a potency): 97%
Estimate against measurement, compound 4: 19 percentage points below, outside the stated range (above it).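

In this assay benzylamino in place of methoxy on a carbonyl carbon, set on the second core, gave a number 2.4 percentage points higher from compound 3 to compound 4 (within the scatter) and so did not repeat the earlier step: the same change on two cores in this assay, a number 16.9 percentage points lower (beyond the scatter) from compound 2 to compound 1 and a number 2.4 percentage points higher (within the scatter) from compound 3 to compound 4, 19.3 percentage points apart, beyond the scatter of two such steps.
In this series, then, the size of this change cannot simply be carried from one core to the other. For the compounds shown here, with only two pairs, each read at a single concentration, the data do not show why the steps differ or what the change would do on a further core.

The compounds shown leave open how a free carboxylic acid or a dimethylamino group on the same carbonyl carbon would read on either core. They also leave open whether a longer chain ending in the amine would alter the gap between the two steps.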